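Cyano for methyl on the aryl ring of compound 2

A few compounds are considered here, and "the series" means these few. Any claim that something is new, unique, unknown or untested is made for them only; others in the source may bear on it.

Measured so far:
compound 1 `C/C(=C\c1cc(-c2ccc(F)nc2)co1)C(N)=O` — > 50000 nM
compound 2 `C/C(=C\c1cc(-c2ccc(C)cc2)cs1)C(N)=O` — > 50000 nM
compound 3 `C/C(=C\c1cccc(-c2ccccc2)c1)C(N)=O` — > 50000 nM

In a functional assay on T-24 cells (Homo sapiens) for cytotoxicity, read by CCK-8 assay, with a stated time of 24 h (a lower number here means a stronger inhibitor, a higher number a weaker inhibitor), compound 1 gives > 50000 nM, which is a limit of the assay and not a number. In this assay compound 2 gives > 50000 nM, again a limit. Compound 3 gives > 50000 nM in this assay, also a limit. So compound 2 stands nowhere apart from the others: all three sit at the limit of > 50000 nM in this assay, at which 3 of the 3 values shown sit, and no step between any pair of them can be sized.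

Compound 4 `C/C(=C\c1cc(-c2ccc(C#N)cc2)cs1)C(N)=O` is not yet measured. It differs from compound 2 by cyano in place of methyl on an aromatic carbon, on an aromatic carbon of a six-membered aromatic ring of carbon only, para to a large group. Going by the values given here, no measured step speaks to this change, and no line of measured evidence assigns any property to the cyano or the methyl.

Among the compounds with values here, with every value shown resting at the limit, the expectation is that compound 4 will also return only a limit in this assay, with no step from compound 2 to compound 4 beyond the scatter. The estimate for compound 4 is 60000 nM, between 15000 nM and 250000 nM, an expected step that the limit leaves unreadable from compound 2 to compound 4.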

Compound 4, half-maximal inhibitory concentration: > 50000 nM
Compound 4 ended at the assay's limit (the forecaster's own chance of this, stated with the estimate: 80%); the middle value does not contradict the limit.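

Compound 4, like compound 2, rests at a limit of the assay and not at a number, so the step for cyano in place of methyl on an aromatic carbon cannot be read: the limit of > 50000 nM in this assay, at which 4 of the 4 values shown sit. The compounds shown leave open which change to the shared core, if any, would give a readable value in this assay.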